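Methoxy for Chloro on a Biaryl Sulfonamide Aniline

The compounds below may be only part of what the source reports. "The series", "measured", "known", "first", "only" and "open" are said of these compounds alone.

Compound 1 `Cc1ccc(CO)cc1NS(=O)(=O)c1ccc(-c2ccc(Br)cc2)cc1`: > 5000 nM
Compound 2 `O=S(=O)(Nc1cc(CO)ccc1Cl)c1ccc(-c2ccc(Br)cc2)cc1`: 2000 nM

In a functional assay on J774 cells (Mus musculus) for cytotoxicity, read by resazurin assay, with a stated time of 72 h (on this read-out higher numbers stand for weaker inhibition and lower numbers for stronger inhibition), compound 2 gives 2000 nM, the only number shown in this series. For compound 1 the value > 5000 nM is a limit of the assay and not a number (the limit of > 5000 nM in this assay, at which 1 of the 2 values shown sits). Among the compounds with values here, the one measured step, an at least 2.5-fold lower number from compound 1 to compound 2 (0.39 log units; beyond the scatter), is the only guide to the position now changed. Compound 3 `COc1ccc(CO)cc1NS(=O)(=O)c1ccc(-c2ccc(Br)cc2)cc1` differs from compound 2 by methoxy in place of chloro on an aromatic carbon. That step speaks to the same aromatic carbon but not to a methoxy group, so its direction for compound 3 is uncertain; methyl at this place sat at the limit while chloro gave a number. The account therefore expects compound 3 to move back toward weaker inhibition, with a 2.0-fold higher number from compound 2 to compound 3 (0.30 log units; within the scatter) as the estimated step, though a result within the scatter of compound 2 remains possible. Compound 3 is estimated at 4000 nM, between 1500 nM and 10000 nM.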

Compound 3, half-maximal inhibitory concentration: 2500 nM
For compound 3 the middle estimate is 1.6-fold (0.20 log units) above the measured one; the range from low to high includes it.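

In this assay, methoxy in place of chloro gives a 1.3-fold higher number from compound 2 to compound 3 (0.10 log units; within the scatter), so at this aromatic carbon, ortho to a large group, the two groups cannot be told apart, although methoxy brings two heavy atoms and a hydrogen-bond acceptor where chloro brings one heavy atom and none. Against methyl the reading is less firm, with an at least 2.0-fold lower number from compound 1 to compound 3 (0.30 log units; that floor lies within the scatter). Only a floor can be given for that step, and it does not clear the scatter, so compound 3 does not settle how methoxy stands against methyl at this place: the limit of > 5000 nM in this assay, at which 1 of the 3 values shown sits.

The compounds shown leave open how an amine, fluoro or a longer chain such as ethoxy would read at this aromatic carbon. Also open, from the compounds shown here alone, is what a carboxylic acid would do in place of the hydroxymethyl group.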